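Shortening the alkylamino substituent from compound 2 to compound 3

A few compounds are considered here, and "the series" means these few. Any claim that something is new, unique, unknown or untested is made for them only; others in the source may bear on it.

Compound 1 `Nc1nc(N2CCCC2)c2ncn(/C=C3/CC3(CO)CO)c2n1` in an ADME assay on BCBL1 cells (Homo sapiens) for cytotoxicity, with a stated time of 7 days (a higher number here means that more compound is tolerated, a lower number that less compound is tolerated), gives > 20000 nM, which is a limit of the assay. Compound 2 `CC(C)Nc1nc(N)nc2c1ncn2/C=C1/CC1(CO)CO` in this assay gives > 20000 nM, again a limit rather than a number. The step that the two limits leave unreadable from compound 1 to compound 2 therefore cannot be sized; the limit of > 20000 nM in this assay, at which 2 of the 2 values shown sit, is all that the measured pair offers. Compound 3 `CNc1nc(N)nc2c1ncn2/C=C1/CC1(CO)CO` differs from compound 2 by methyl in place of isopropyl on a nitrogen on an aromatic ring. Among the measured compounds shown here, no measured step bears on this change, and nothing points to a step beyond the scatter in this assay, so compound 3 is expected to sit at the limit again. Compound 3 is estimated at 30000 nM in this assay, between 12000 nM and 80000 nM, the expected step being a step that the limit leaves unreadable from compound 2 to compound 3.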

Compound 3, half-maximal cytotoxic concentration: 67000 nM
Compound 3: middle estimate off by 2.2-fold (0.35 log units), on the low side; measured number inside the range.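

Compound 3 gives a number, but its steps from compound 1 and compound 2 in this assay cannot be read, as the other two values are limits: the limit of > 20000 nM in this assay, at which 2 of the 3 values shown sit.

On these data alone, whether the amino substituent changes the tolerated concentration across compound 1, compound 2 and compound 3 stays open.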